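Adding a Second Hydroxy Group to a Chalcone-Like Scaffold

The source may report more compounds than this note shows. Statements on the series, on what has been measured and on what is new or still open speak of the compounds shown alone.

This small series shares one core, a phenolic ketone joined through a chain to a second phenol ring. Compound 1 `O=C(/C=C(O)/C=C/c1ccc(O)c(O)c1)c1ccccc1O` carries two hydroxy groups on the far ring. In an assay on isolated protein for inhibition of Alpha glucosidase (Homo sapiens), with stated times of 5 min and 15 min (a lower number here means a stronger inhibitor, a higher number a weaker inhibitor), compound 1 gives 14300 nM, a weak result. Compound 2 `O=C(/C=C(O)/C=C/c1ccc(O)cc1)c1cc(Cl)ccc1O` has a chlorine on the ketone side, and for compound 2 this assay records only "not determined" (no result reported). Compound 3 `O=C(/C=C(O)/C=C/c1ccc(O)cc1)c1ccccc1O` keeps a single hydroxy group on the far ring, and for compound 3 this assay likewise records "not determined" (no result reported). So compound 3 has no number of its own to stand on; the only measured point in the family is compound 1.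

Compound 4 `O=C(/C=C(O)/C=C/c1ccc(O)cc1O)c1ccccc1O` is compound 3 with one change: hydroxy in place of hydrogen on an aromatic carbon. The new group sits on the far ring, ortho to a large group and meta to the existing hydroxy group. Among the measured compounds shown here, no measured pair in this set shows what such a change does, so no step size can be quoted; with only compound 1 as an anchor, no shift beyond the usual scatter is expected in either direction.

Compound 4 is therefore expected to come out near 15000 nM, with a plausible range from 4000 nM to 60000 nM, because compound 1 gives 14300 nM as the closest measured relative.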

Compound 4, half-maximal inhibitory concentration: 40700 nM
Compound 4: the middle estimate sits 2.7-fold (0.43 log units) below what was measured; low and high end bracket the measured number.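

Compound 3 has no single number in this assay, so the change from compound 3 to compound 4 cannot be read as a step. The compounds shown leave open what the added hydroxy group does to inhibition on the shared core. Nothing further here helps to explain the value of compound 4.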